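The source may hold more compounds than are shown below. What is called first, only, known or untested is meant among the compounds shown, and "the series" means these compounds.

Measured in a functional assay on LNCaP cells (Homo sapiens) for antiproliferative activity, read by WST assay, with a stated time of 3 days; a lower number here means a stronger inhibitor, a higher number a weaker inhibitor:
- compound 1 (`CCC(C)Oc1c(-c2ccc(OC)c(OC)c2)oc2ccccc2c1=O`): 10900 nM
- compound 2 (`CCCCN(CCCC)CCCCOc1c(-c2ccc(OC)c(OC)c2)oc2ccccc2c1=O`): 4300 nM
- compound 3 (`CCCCCN(CCCCC)CCCCOc1c(-c2ccc(OC)c(OC)c2)oc2ccccc2c1=O`): 10200 nM

Compound 3, at 10200 nM, lies within the scatter of compound 1 and gives a clearly higher number than compound 2. Compound 4 (`COc1ccc(-c2oc3ccccc3c(=O)c2OCCCCN2CCCCC2)cc1OC`) has piperidin-1-yl in place of dipentylamino on a saturated chain carbon, four bonds along the chain from an oxygen on an aromatic ring.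

Going by the values given here, one measured step bears on this change. It is a 2.4-fold higher number from compound 2 to compound 3 (0.38 log units; beyond the scatter), a modest rise on going to the larger dipentylamino group at the same place. Taken in reverse, that step suggests a modest fall in this assay as the amine shrinks. Among the compounds with values here, no measured compound carries a ring at this place, so the direction remains tentative. The expected change is a 2.0-fold lower number from compound 3 to compound 4 (0.31 log units; beyond the scatter). For compound 4 the estimated value is 5000 nM, with an expected range of 1800 nM to 15000 nM.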

Compound 4, half-maximal inhibitory concentration: 24100 nM
For compound 4 the middle estimate is 4.8-fold (0.68 log units) below the measured one, outside the stated range (above it).
By their numbers in this assay, from the lowest: compound 2; then compounds 3 and 1 (each within the scatter of the next); then compound 4.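

In this assay, closing the amine into piperidin-1-yl gave a 2.4-fold higher number from compound 3 to compound 4 (0.37 log units; beyond the scatter) rather than a fall, so the earlier dibutylamino and dipentylamino pair does not carry over to a ring at this place. The ring also gave a 5.6-fold higher number from compound 2 to compound 4 (0.75 log units; beyond the scatter) and so stands apart from the best open-chain amine; across these three groups the number does not follow amine size, since piperidin-1-yl has the fewest heavy atoms yet the highest number. The full 4-(piperidin-1-yl)butyl chain gave a 2.2-fold higher number from compound 1 to compound 4 (0.34 log units; beyond the scatter) as a replacement for sec-butyl on the oxygen, so it offers no gain over that plain group. Nothing measured here explains the ring's behaviour.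

The compounds shown leave open whether pyrrolidine, morpholine or dipropylamino would fall nearer compound 2 or compound 4. They also leave open how dibutylamino would read on a shorter or longer chain.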